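The source may hold more compounds than are shown below. What is called first, only, known or untested is meant among the compounds shown, and "the series" means these compounds.

Measured compounds:
Compound 1 `O=S(=O)(c1ccc(O)nn1)c1ccc(Br)cc1F`: 67%
Compound 2 `Cc1c(S(=O)(=O)c2ccc(O)nn2)oc2ccccc12`: 43%
Compound 3 `Cc1c(S(=O)(=O)c2ccc(O)nn2)oc2cc(Cl)ccc12`: 28%

In a functional assay on the whole organism for inhibition, with Rattus norvegicus as the target, with a stated time of 60 min, at pH 4.5, at a dose of 10 mg/kg by the oral route (on this read-out higher numbers stand for a stronger effect at the one dose given and lower numbers for a weaker effect), compound 2 gives 43%, the second highest of the three numbers; compound 1 gives 67% and compound 3 gives 28%. Compound 4 `O=S(=O)(c1ccc(O)nn1)c1oc2ccccc2c1-c1ccc(F)cc1` differs from compound 2 in one place: 4-fluorophenyl in place of methyl on an aromatic carbon. Going by the values given here, the only measured step, a number 15 percentage points lower from compound 2 to compound 3 (beyond the scatter), changes a different place on the fused ring system, so it does not directly bear on this exchange; no measured step replaces the methyl. With that single, indirect precedent pointing downward, compound 4 is expected to show a modest drop, a number 8 percentage points lower from compound 2 to compound 4 (within the scatter), with wide uncertainty. The estimate for compound 4 in this assay is 35%, expected to fall between 10% and 60%.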

Compound 4, a percentage reported as inhibition, in the whole organism at one dose (the size of the read-out at that dose, not a potency): 50%
Beside the measured number, compound 4's estimate is 15 percentage points below it; the measured number falls inside the stated range.
By their numbers in this assay, from the lowest: compound 3; then compounds 2 and 4 (each within the scatter of the next); then compound 1.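

In this assay, putting 4-fluorophenyl in place of methyl on this aromatic carbon gives a number 7 percentage points higher from compound 2 to compound 4 (within the scatter). This position, two ring bonds from the ring oxygen, therefore accepts a group of 7 heavy atoms with its own aromatic ring in place of a single carbon, and the read-out stays within the usual scatter. Nothing available explains this result.

Going by these compounds, whether a plain phenyl, an amine or a carboxylic acid on this carbon would give a similar read-out remains open. A single dose also leaves open how the effects of these two compounds would compare at other doses.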